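The compounds below may be only part of what the source reports. "The series", "measured", "known", "first", "only" and "open" are said of these compounds alone.

Series notes, step from compound 2 to compound 3.

In a functional assay on cells for antagonist activity at C-X-C chemokine receptor type 4 (Homo sapiens), read by fluorescence and calcium flux, with stated times of 25 min and 90 s (on this read-out lower numbers stand for stronger inhibition and higher numbers for weaker inhibition), compound 1 `c1ccc2c(c1)CN[C@@H](CN(CCCCNCC1CCOCC1)[C@H]1CCCc3cccnc31)C2` gives 52.9 nM and compound 2 `c1ccc2c(c1)CN[C@@H](CN(CCCCNC1CCSCC1)[C@H]1CCCc3cccnc31)C2` gives 54.7 nM. For the measured compounds named here, compound 2 stands highest of the two numbers measured so far, but the step between the two is a 1.0-fold higher number from compound 1 to compound 2 (0.01 log units; within the scatter) and so the two compounds are indistinguishable on this read-out. Compound 3 `NCc1cccc(CN(C[C@H]2Cc3ccccc3CN2)[C@H]2CCCc3cccnc32)c1` differs from compound 2 by a group of 8 heavy atoms (7 carbon, 1 nitrogen; one six-membered aromatic ring of carbon only) in place of a group of 10 heavy atoms (8 carbon, 1 nitrogen, 1 sulfur; one six-membered non-aromatic ring with 1 hetero atom), on a saturated chain carbon bound to an amine nitrogen. Going by the values given here, the one measured step, from thian-4-yl in place of (oxan-4-yl)methyl on an amine nitrogen, alters the terminal ring only and leaves the chain intact, so it does not bear directly on the present change, which removes the whole chain and its ring. Among the compounds with values here, no measured step therefore sets a direction, and the expectation for compound 3 in this assay rests on the unchanged shared core alone: a step of a 1.1-fold higher number from compound 2 to compound 3 (0.04 log units; within the scatter) is estimated, with a broad range. Compound 3 is expected at 60 nM, between 12 nM and 300 nM.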

Compound 3, half-maximal inhibitory concentration: 292 nM
Compound 3: middle estimate off by 4.9-fold (0.69 log units), on the low side, and the stated range covers the measured number.
By their numbers in this assay, from the lowest: compounds 1 and 2 (each within the scatter of the next); then compound 3.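

In this assay the change at this saturated chain carbon gives a 5.3-fold higher number from compound 2 to compound 3 (0.73 log units; beyond the scatter) and a 5.5-fold higher number from compound 1 to compound 3 (0.74 log units; beyond the scatter) and is thus the first in the series to move the number beyond the scatter, though both steps are modest. Compounds 1 and 2, with their different saturated terminal rings, did not separate on this read-out, whereas 3-(aminomethyl)phenyl in place of those groups shows that this position does respond to a change, in the direction of weaker inhibition. Nothing at hand accounts for this result.

Going by these compounds, the change replaces the chain and the terminal ring at once, so the part of it that carries the step stays open. A plain phenyl group, or an open alkyl chain ending in a primary amine, would help to separate the aromatic ring from the amine.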